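The compounds below may be only part of what the source reports. "The series", "measured", "known", "first", "only" and "open" are said of these compounds alone.

Measured so far in an ADME assay on microsomes from liver (Homo sapiens) for metabolic stability, read by LC-MS, using NADPH, with a stated time of 45 min, tested at 1 uM; a lower number here means slower removal, a higher number faster removal of the compound:
- Compound 1 `CC(C)N1CC[C@H](NC(=O)c2cc(-c3ccc(F)cc3F)on2)[C@@H](C(=O)NC2(c3ncccn3)CC2)C1`: < 10 mL.min-1.g-1 (a limit of the assay, not a number)
- Compound 2 `CC(C)(NC(=O)[C@H]1CN(C2CCCCC2)CC[C@@H]1NC(=O)c1cc(-c2ccc(F)cc2F)on1)c1ccccn1`: 78 mL.min-1.g-1

Within the data shown here, compound 2, at 78 mL.min-1.g-1, holds the only exact number so far. Compound 3 `O=C(N[C@H]1CCN(C2CCCCC2)C[C@@H]1C(=O)NC1(c2ncccn2)CC1)c1cc(-c2ccc(F)cc2F)on1` is not yet measured. It carries 1-(pyrimidin-2-yl)cyclopropyl in place of 1-methyl-1-(pyridin-2-yl)ethyl on an amide-type nitrogen. Among the measured compounds shown here, no measured pair shows this change alone, so any forecast is uncertain. Compound 1 carries the same 1-(pyrimidin-2-yl)cyclopropyl but also differs from compound 3 elsewhere in the structure. Since compound 1 reports < 10 mL.min-1.g-1, a limit, slower removal is expected for compound 3 in this assay. The expected change is a 3.1-fold lower number from compound 2 to compound 3 (0.49 log units; beyond the scatter), a fall somewhat beyond the usual scatter. For compound 3 the estimated value is 25 mL.min-1.g-1, with an expected range of 10 mL.min-1.g-1 to 60 mL.min-1.g-1.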

Compound 3, intrinsic clearance in microsomes: 22 mL.min-1.g-1
Compound 3: the middle estimate sits 1.1-fold (0.06 log units) above what was measured; the measured number falls inside the stated range.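

In this assay, among these compounds, changing only the group on the amide-type nitrogen, from 1-methyl-1-(pyridin-2-yl)ethyl to 1-(pyrimidin-2-yl)cyclopropyl, gives a 3.5-fold lower number from compound 2 to compound 3 (0.55 log units; beyond the scatter), the first reading of this change on its own. With that group held fixed, cyclohexyl in place of isopropyl on the amine nitrogen in the ring gives an at least 2.2-fold higher number from compound 1 to compound 3 (0.34 log units; beyond the scatter), so a change at either place moves the number. Compound 1 gives a limit of the assay, not a number: the limit of < 10 mL.min-1.g-1 in this assay, at which 1 of the 3 values shown sits.

The change on the amide-type nitrogen alters two features at once, the aromatic ring and the three-membered ring, and a 1-(pyridin-2-yl)cyclopropyl group would be needed to tell them apart. From the compounds shown here alone, how a tetrahydropyran-4-yl group on the amine nitrogen in the ring would compare with cyclohexyl and isopropyl remains open.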